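The source may hold more compounds than are shown below. What is called first, only, known or untested is meant among the compounds shown, and "the series" means these compounds.

In an assay on HEK293 cells for binding affinity to Urotensin-2 receptor (Homo sapiens), read by radioligand binding (a higher number here means a weaker inhibitor, a lower number a stronger inhibitor), compound 3 `CC(C)C[C@H](NC(=O)c1cc2ccccc2o1)C(=O)N[C@H]1CCN(Cc2ccc(OCCCN(C)C)cc2)C1` gives 158 nM, the lowest of the two numbers in the series. Compound 2 `CN(C)CCCOc1ccc(CN2CC[C@H](NC(=O)c3cc4ccccc4o3)C2)cc1` gives 2510 nM, a gap beyond the scatter. For compound 1 `CC(=O)N[C@H]1CCN(Cc2ccc(OCCCN(C)C)cc2)C1` only a limit is recorded, < 10000 nM, which is the limit of < 10000 nM in this assay, at which 1 of the 3 values shown sits. The step that the limit leaves unreadable from compound 1 to compound 2 is consequently of unreadable size. Compound 4 `CC(=O)N[C@@H](CC(C)C)C(=O)N[C@H]1CCN(Cc2ccc(OCCCN(C)C)cc2)C1` differs from compound 3 in one place: methyl in place of 1-benzofuran-2-yl on a carbonyl carbon. Among the measured compounds shown here, that change is the reverse of the one from compound 1 to compound 2, whose size cannot be read because of the limit of < 10000 nM in this assay, at which 1 of the 3 values shown sits. For the measured compounds named here, the only usable anchor is compound 3 with 158 nM. Compound 4 is expected to bind more weakly, the step of a 19-fold higher number from compound 3 to compound 4 (1.28 log units; beyond the scatter) towards a higher number. The estimate for compound 4 is 3000 nM, with a range from 600 nM to 12000 nM.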

Compound 4, inhibition constant: 2510 nM
Estimate against measurement, compound 4: 1.2-fold (0.08 log units) above; the measured number falls inside the stated range.
By their numbers in this assay, from the lowest: compound 3; then compounds 2 and 4 (each within the scatter of the next).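

In this assay, methyl in place of 1-benzofuran-2-yl on a carbonyl carbon now has a readable size: a 16-fold higher number from compound 3 to compound 4 (1.20 log units; beyond the scatter). Replacing 1-benzofuran-2-yl with 1-acetamido-3-methylbutyl on a carbonyl carbon gives no change at the digits printed from compound 2 to compound 4 (within the scatter), so only compound 3, which carries both groups, stands apart. Steps from compound 1 cannot be read, as its value is a limit: the limit of < 10000 nM in this assay, at which 1 of the 4 values shown sits.

From the compounds shown here alone, whether a phenyl or a cyclohexyl in place of 1-benzofuran-2-yl on this carbonyl carbon would hold the number of compound 3 stays open. So does the effect of a longer chain in place of methyl.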